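Methoxy for phenyl: from compound 1 to compound 3

This account rests on a few compounds, and the source may have more. Where it says the series, first, only, none or still open, it means among the compounds named here.

Two compounds of the series carry numbers in a functional assay on NCI-H522 cells (Homo sapiens) for inhibition, read by sulforhodamine B assay, with a stated time of 48 h, tested at 10 uM; a higher number here means more inhibition of growth at the concentration tested, a lower number less inhibition of growth. Compound 1 `CC(=O)c1cccc(Nc2ccnc(SCC(=O)c3ccc(-c4ccccc4)cc3)n2)c1` gives 38% in this assay. Compound 2 `CC(=O)c1ccc(Nc2ccnc(SCC(=O)c3ccc(Cl)cc3)n2)cc1` gives 29% in this assay. Compound 1 stands at the higher of the two numbers, but its gap to compound 2 lies within the scatter of repeated runs, so the two cannot be placed in order on this evidence. Both compounds reach only modest growth inhibition at the single concentration tested. For the measured compounds named here, no pair of measured compounds differs in one place only, so the set gives no single-change step from which the size of such a step in this assay could be read.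

Compound 3 `COc1ccc(C(=O)CSc2nccc(Nc3cccc(C(C)=O)c3)n2)cc1` is not yet measured in this assay. It differs from compound 1 in one place: methoxy in place of phenyl on an aromatic carbon. Going by the values given here, with no single-change step available, nothing in the numbers points to a direction for this change. The step from compound 1 to compound 3 is expected to be a number 6 percentage points lower from compound 1 to compound 3 (within the scatter), a size not beyond the scatter, in either direction. Compound 3 is therefore estimated at 32% in this assay, with a range from 12% to 52%.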

Compound 3, percent growth inhibition at one concentration: 37%
For compound 3 the middle estimate is 5 percentage points below the measured one; the range from low to high includes it.
By their numbers in this assay, from the lowest: compounds 2, 3 and 1 (each within the scatter of the next).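

The series now has its first single-change step in this assay: methoxy in place of phenyl on an aromatic carbon gives a number 1 percentage points lower from compound 1 to compound 3 (within the scatter). At this place, para to a large group, a six-membered aromatic ring of carbon only with 6 heavy atoms can therefore be exchanged for a group of 2 heavy atoms with 1 hydrogen-bond acceptor, and the read-out does not separate the two compounds. Nothing on hand explains why the two groups read alike.

Open, on these data alone, is whether this place stays as undemanding with a group that has a hydrogen-bond donor or a net charge, such as an amine or a carboxylic acid, or with a longer chain such as butoxy, since phenyl and methoxy alone cannot show how far the insensitivity extends. Also open, as far as these compounds go, is whether the same exchange would read alike on the core of compound 2, and whether it would stay this small at concentrations other than the single one behind these percentages.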